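The compounds below may be only part of what the source reports. "The series", "measured", "known", "first", "only" and "open" are said of these compounds alone.

Compound 2 `CCCO/N=C/c1c(N)ncnc1Oc1ccc2[nH]c(C)cc2c1F` is examined in a functional assay on A-375 cells (Homo sapiens) for antiproliferative activity (a lower number here means a stronger inhibitor, a higher number a weaker inhibitor), where compound 2 gives 28 nM. Among the three measured compounds this is the second highest number. Compound 1 `CCO/N=C/c1c(N)ncnc1Oc1ccc2[nH]c(C)cc2c1F` gives 27 nM, and the step of a 1.0-fold higher number from compound 1 to compound 2 (0.02 log units; within the scatter) lies within the scatter. Compound 3 `CO/N=C/c1c(N)ncnc1Oc1ccc2[nH]cc(C)c2c1` gives 132 nM, a higher number than compound 2 that lies beyond the scatter. Compound 4 `Cc1cc2c(F)c(Oc3ncnc(N)c3/C=N/OCc3ccccc3)ccc2[nH]1` carries the change (phenyl in place of ethyl on a saturated chain carbon bound to an oxygen on an unsaturated carbon), so that propyl becomes benzyl. For the measured compounds named here, only the step from compound 1 to compound 2 touches this chain, and it was flat; no measured step shows a phenyl entering at this place. The expected step of a 1.3-fold higher number from compound 2 to compound 4 (0.10 log units; within the scatter) is therefore modest, with no clear direction. Compound 4 is estimated at 35 nM, with a range from 12 nM to 100 nM.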

Compound 4, half-maximal inhibitory concentration: 62 nM
Estimate against measurement, compound 4: 1.8-fold (0.25 log units) below; low and high end bracket the measured number.
By their numbers in this assay, from the lowest: compounds 1 and 2 (each within the scatter of the next); then compound 4; then compound 3.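

In this assay the phenyl does what the earlier chain step did not: it moves the number, with a 2.2-fold higher number from compound 2 to compound 4 (0.35 log units; beyond the scatter) and with a 2.3-fold higher number from compound 1 to compound 4 (0.36 log units; beyond the scatter) as well. For the compounds shown here, the only earlier change at this place, a 1.0-fold higher number from compound 1 to compound 2 (0.02 log units; within the scatter), gave no such shift, so this position responds to the phenyl with a modest rise and no more. Nothing measured here accounts for that rise. From the compounds shown here alone, whether a butyl chain, a phenethyl group or a benzyl carrying an amine would bring the number back to that of compound 1 stays open.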